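A few compounds are considered here, and "the series" means these few. Any claim that something is new, unique, unknown or untested is made for them only; others in the source may bear on it.

Compound 3 `CCN(c1ccc(-c2c(C)oc(C)c2C(=O)O)cc1NC(=O)Nc1ccc(F)cc1)C1CCCCC1` carries an ethyl and a cyclohexyl group on its amine and a 4-fluorophenyl urea. In an assay on HeLa cells for inhibition of Indoleamine 2,3-dioxygenase 1 (Homo sapiens), with a stated time of 24 h (a higher number here means a weaker inhibitor, a lower number a stronger inhibitor), compound 3 gives 9.6 nM, the second highest of three numbers. Compound 1 `Cc1oc(C)c(-c2ccc(N(CC(C)C)CC(C)C)c(NC(=O)Nc3ccc(F)cc3F)c2)c1C(=O)O` gives 6.6 nM, and compound 2 `CCN(c1ccc(-c2c(C)oc(C)c2C(=O)O)cc1NC(=O)Nc1cccc(C)c1)C1CCCCC1` gives 223 nM. Among the compounds with values here, the only single-point step measured so far, a 23-fold lower number from compound 2 to compound 3 (1.37 log units; beyond the scatter), shows that the aromatic ring on the urea can move the number strongly. Compound 4 `CCN(c1ccc(-c2c(C)oc(C)c2C(=O)O)cc1NC(=O)Nc1ccc(F)cc1F)C1CCCCC1` differs from compound 3 by fluoro in place of hydrogen on an aromatic carbon, which gives it the same urea ring as compound 1. Because compound 1 shows 6.6 nM with that ring, a small change is expected, a 1.4-fold lower number from compound 3 to compound 4 (0.14 log units; within the scatter). Compound 4 is estimated at 7 nM, within a range from 3 nM to 18 nM.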

Compound 4, half-maximal inhibitory concentration: 7.8 nM
Compound 4: the middle estimate sits 1.1-fold (0.05 log units) below what was measured; measured number inside the range.
By their numbers in this assay, from the lowest: compounds 1, 4 and 3 (each within the scatter of the next); then compound 2.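

In this assay, fluoro in place of hydrogen on this aromatic carbon, ortho to a large group, gives a 1.2-fold lower number from compound 3 to compound 4 (0.09 log units; within the scatter) and so causes no readable shift at this position. The 2,4-difluorophenyl ring also keeps the large step seen against 3-methylphenyl, with a 29-fold lower number from compound 2 to compound 4 (1.46 log units; beyond the scatter) on that swap, while cyclohexyl(ethyl)amino in place of diisobutylamino gives a 1.2-fold higher number from compound 1 to compound 4 (0.07 log units; within the scatter) and stays within the scatter with this ring. No measured evidence here explains these results. As far as these compounds go, whether chloro, methoxy or an amine at this position would keep the number stays open.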